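Working notes: chloro to bromo step in a cytotoxicity series

This account rests on a few compounds, and the source may have more. Where it says the series, first, only, none or still open, it means among the compounds named here.

Measured compounds:
compound 1 `O=C(/C=C/c1ccc2c(c1)B(O)OC2)c1ccco1` gives 7300 nM
compound 2 `O=C(/C=C/c1ccc2c(c1)B(O)OC2)c1ccc(Cl)cc1` gives 7900 nM

In a functional assay on MDA-MB-231 cells (Homo sapiens) for cytotoxicity, read by MTT assay, with a stated time of 48 h (on this read-out lower numbers stand for stronger inhibition and higher numbers for weaker inhibition), compound 2 holds the higher of the two numbers, with compound 1 nearest. Going by the values given here, the only measured step, a 1.1-fold higher number from compound 1 to compound 2 (0.03 log units; within the scatter), swapped furan-2-yl for 4-chlorophenyl on the carbonyl carbon and stayed within the scatter. Compound 3 `O=C(/C=C/c1ccc2c(c1)B(O)OC2)c1ccc(Br)cc1` differs from compound 2 by bromo in place of chloro on an aromatic carbon. Among the compounds with values here, no measured step bears directly on a halogen exchange; the single step known is small, so no step beyond the scatter is expected, no change at the digits printed from compound 2 to compound 3 (within the scatter). In this assay compound 3 is expected to give 7900 nM, within 4000 nM to 16000 nM.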

Compound 3, half-maximal inhibitory concentration: 9500 nM
The estimate for compound 3 lay 1.2-fold (0.08 log units) below the measured number; the range from low to high includes it.
By their numbers in this assay, from the lowest: compounds 1, 2 and 3 (each within the scatter of the next).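

In this assay, bromo in place of chloro gives a 1.2-fold higher number from compound 2 to compound 3 (0.08 log units; within the scatter), so this halogen exchange on the aromatic carbon does not separate the two compounds. With 4-bromophenyl in place of furan-2-yl on the carbonyl carbon, the series shows a 1.3-fold higher number from compound 1 to compound 3 (0.11 log units; within the scatter), which adds a second aryl change that stays within the scatter. No evidence on the cause of these numbers is available.

On these data alone, whether an amine or a carboxylic acid at this aromatic carbon would give a step beyond the scatter remains open. As far as these compounds go, the effect of changes to the shared core also remains open.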